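The source may report more compounds than this note shows. Statements on the series, on what has been measured and on what is new or still open speak of the compounds shown alone.

Measured so far:
- Compound 1 `COC(=O)c1scc(-c2ccc(NC(=O)c3ccccn3)cc2)c1OC`: 10300 nM
- Compound 2 `COC(=O)c1scc(-c2ccc(NC(=O)c3cccc(I)c3)cc2)c1OC`: 16500 nM
- Compound 3 `COC(=O)c1scc(-c2ccc(NC(=O)c3cc(I)ccc3F)cc2)c1OC`: "not determined" (no result reported)

In a functional assay on HepG2 cells (Homo sapiens) for antiproliferative activity, read by MTT assay, with a stated time of 24 h (on this read-out lower numbers stand for stronger inhibition and higher numbers for weaker inhibition), compound 3 has no single number: its entry reads "not determined" (no result reported). It therefore offers no starting value, and any expectation has to come from its neighbours.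

The next compound, compound 4 `COC(=O)c1scc(-c2ccc(NC(=O)c3ccc(C#N)nc3)cc2)c1OC`, has not yet been measured. It differs from compound 3 at one place: 6-cyanopyridin-3-yl in place of 2-fluoro-5-iodophenyl on a carbonyl carbon. In words, this is 6-cyanopyridin-3-yl in place of 2-fluoro-5-iodophenyl on a carbonyl carbon.

Within the data shown here, only one measured step bears on this kind of exchange: a 1.6-fold higher number from compound 1 to compound 2 (0.20 log units; within the scatter). It swaps 3-iodophenyl for pyridin-2-yl at the same kind of place and stays within the scatter. On this single step, no change beyond the scatter is expected in this assay from swapping one of these rings for another, so no direction can be given. Compound 4 is expected to fall in the same region as compound 1, at 10300 nM, and compound 2, at 16500 nM.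

For compound 4 the estimated value is 13000 nM, with an expected range of 5000 nM to 33000 nM.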

Compound 4, half-maximal inhibitory concentration: 22500 nM
For compound 4 the middle estimate is 1.7-fold (0.24 log units) below the measured one, within the range that was stated.
By their numbers in this assay, from the lowest: compounds 1, 2 and 4 (each within the scatter of the next, the first and the last beyond it).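

In this assay the ring on the carbonyl carbon now shows its first exchange beyond the scatter: a 2.2-fold higher number from compound 1 to compound 4 (0.34 log units; beyond the scatter) when 6-cyanopyridin-3-yl takes the place of pyridin-2-yl. The exchange of 3-iodophenyl for 6-cyanopyridin-3-yl gives a 1.4-fold higher number from compound 2 to compound 4 (0.13 log units; within the scatter) so these two rings cannot be told apart on this read-out, even though one is a carbon-only iodinated ring and the other carries a nitrile. Nothing measured here explains why these numbers stand where they do.

As far as these compounds go, compound 3 has no result, so steps to it cannot be read and the effect of 2-fluoro-5-iodophenyl stays open. Every compound shown carries an aromatic ring on this carbonyl carbon, so it remains open how this assay would respond to a longer chain there, or to a group bearing an amine or a carboxylic acid.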